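Ethoxycarbonyl to Isopropoxycarbonyl: One More Methyl

This account rests on a few compounds, and the source may have more. Where it says the series, first, only, none or still open, it means among the compounds named here.

- compound 1 `COC(=O)c1cc(CCCOc2c(C)cc(-c3noc(C(F)(F)F)n3)cc2C)on1` gives 35400 nM
- compound 2 `CCOC(=O)c1cc(CCCOc2c(C)cc(-c3noc(C(F)(F)F)n3)cc2C)on1` gives 17200 nM
- compound 3 `CCOC(=O)c1cc(CCCOc2ccc(-c3noc(C(F)(F)F)n3)cc2C)on1` gives 35100 nM

These numbers come from an ADME assay on HeLa cells (Homo sapiens) for cytotoxicity, read by crystal violet staining, with a stated time of 72 h (a lower number here means that less compound is tolerated, a higher number that more compound is tolerated), and among the three, compound 2 has the lowest, 17200 nM, so it is the one tolerated least by the cells. Compound 4 `Cc1cc(-c2noc(C(F)(F)F)n2)cc(C)c1OCCCc1cc(C(=O)OC(C)C)no1` differs from compound 2 in one place, turning ethoxycarbonyl into isopropoxycarbonyl: methyl in place of hydrogen on a saturated chain carbon bound to an oxygen next to a carbonyl group and a saturated chain carbon.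

The most relevant measured step is also methyl in place of hydrogen on a saturated chain carbon bound to an oxygen next to a carbonyl group: a 2.1-fold lower number from compound 1 to compound 2 (0.31 log units; beyond the scatter). Within the data shown here, this modest step is the only direct guide. The other step, a 2.0-fold higher number from compound 2 to compound 3 (0.31 log units; beyond the scatter), is hydrogen in place of methyl on an aromatic carbon, a different place, so it says little here.

A similar or somewhat smaller move towards a lower number is therefore expected in this assay, though it could stay within the scatter. The expected step is a 1.5-fold lower number from compound 2 to compound 4 (0.17 log units; within the scatter), which is only an estimate. Compound 4 is estimated at 11500 nM, with an expected range of 6000 nM to 22000 nM.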

Compound 4, half-maximal cytotoxic concentration: 17900 nM
Beside the measured number, compound 4's estimate is 1.6-fold (0.19 log units) below it, within the range that was stated.
By their numbers in this assay, from the lowest: compounds 2, 4, 3 and 1 (each within the scatter of the next, the first and the last beyond it).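

In this assay, the extra methyl that turns ethoxycarbonyl into isopropoxycarbonyl leaves the number within the scatter (a 1.0-fold higher number from compound 2 to compound 4 (0.02 log units; within the scatter)), unlike the earlier methyl added at this same group (a 2.1-fold lower number from compound 1 to compound 2 (0.31 log units; beyond the scatter)). The wider change from methyl to isopropyl on that oxygen also stays within the scatter (a 2.0-fold lower number from compound 1 to compound 4 (0.30 log units; within the scatter)), so compound 4 goes against any idea that each added carbon here pushes the number further down. No measurement on hand explains why the two added methyl groups differ.

Still open, on these data alone, is whether a tert-butyl group on that oxygen, or a carboxylic acid in place of the whole isopropoxycarbonyl group, would stay in this range. Also open, as far as these compounds go, is whether swapping an aromatic methyl for hydrogen would act on compound 4 as it did on compound 2.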